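The source may report more compounds than this note shows. Statements on the series, on what has been measured and on what is new or still open speak of the compounds shown alone.

Measured so far in an ADME assay on MT4 cells (Homo sapiens) for cytotoxicity, read by MTT assay; a lower number here means that less compound is tolerated, a higher number that more compound is tolerated:
- compound 1 `O=C(CSc1nncnc1-c1cccc2ccccc12)Nc1ccccc1`: 154000 nM
- compound 2 `O=C(CSc1nncnc1-c1cccc2ccccc12)Nc1ccccc1Cl`: 63000 nM

Of these two, compound 2 has the lower number, at 63000 nM, so it is the less tolerated of the pair. The next compound is compound 3 `O=C(CSc1nncnc1-c1cccc2ccccc12)Nc1ccccc1F`, with this change: fluoro in place of chloro on an aromatic carbon. This places fluoro in place of chloro on an aromatic carbon, ortho to a large group. For the measured compounds named here, only one measured step bears on it, the arrival of chloro in place of hydrogen on an aromatic carbon: a 2.4-fold lower number from compound 1 to compound 2 (0.39 log units; beyond the scatter). Going by the values given here, no fluoro compound has been measured, so that modest step serves only as a rough upper guide. A partial return towards the higher number is expected, smaller than that step and probably inside the scatter. The expected move is a 1.6-fold higher number from compound 2 to compound 3 (0.20 log units; within the scatter). For compound 3 the estimate is 100000 nM, with an expected range of 50000 nM to 200000 nM.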

Compound 3, half-maximal cytotoxic concentration: 65000 nM
Estimate against measurement, compound 3: 1.5-fold (0.19 log units) above, within the range that was stated.
By their numbers in this assay, from the lowest: compounds 2 and 3 (each within the scatter of the next); then compound 1.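

In this assay, fluoro in place of chloro on an aromatic carbon, ortho to a large group, gives a 1.0-fold higher number from compound 2 to compound 3 (0.01 log units; within the scatter), so the two halogens cannot be told apart at this position. Fluoro in place of hydrogen gives a 2.4-fold lower number from compound 1 to compound 3 (0.37 log units; beyond the scatter), which shows that the step away from compound 1 is not confined to chloro. No measurement bears on what lies behind this shared result.

Going by these compounds, whether the step from compound 1 belongs to halogens as a class or to any group at this position remains open, and a methyl, methoxy or amine group here would test that. Also open, on these data alone, is whether chloro or fluoro would give a similar step at another place on the same ring.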